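Series notes: truncating the benzyl ether toward compound 3

This account rests on a few compounds, and the source may have more. Where it says the series, first, only, none or still open, it means among the compounds named here.

Measured so far:
compound 1 `O=C1NC(=S)S/C1=C\C=C\c1cc(Br)ccc1OCc1ccccc1Br`: 40.3%
compound 2 `O=C1NC(=S)S/C1=C\C=C\c1ccccc1OCc1ccccc1Br`: 63.1%

Both numbers come from an assay on isolated protein for inhibition of protein tyrosine phosphatase type IVA 3 (Homo sapiens), tested at 5 ug/mL; a higher number here means more inhibition at the concentration tested (going by the name of the read-out), a lower number less inhibition. Within the data shown here, compound 2 stands highest of the two measured numbers; its only neighbour is compound 1, and the step between them is a number 22.8 percentage points higher from compound 1 to compound 2 (beyond the scatter), beyond the scatter.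

Compound 3 `COc1ccccc1/C=C/C=C1\SC(=S)NC1=O` is not yet measured. It differs from compound 2 by hydrogen in place of 2-bromophenyl on a saturated chain carbon bound to an oxygen on an aromatic ring. Among the measured compounds shown here, the single measured step concerns hydrogen in place of bromo on an aromatic carbon, a far smaller change than removing the whole 2-bromophenyl; it shows that trimming this side of the molecule can raise inhibition, but gives no direct reading on losing the ring itself. For the measured compounds named here, with no closer precedent, a drop in inhibition is expected, a number 25.1 percentage points lower from compound 2 to compound 3 (beyond the scatter). For compound 3 the estimate in this assay is 38%, with a range of 15% to 62%.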

Compound 3, a percentage reported as inhibition, at one concentration (the size of the read-out at that concentration, not a potency): 41.7%
Compound 3: middle estimate off by 3.7 percentage points, on the low side, within the range that was stated.
By their numbers in this assay, from the lowest: compounds 1 and 3 (each within the scatter of the next); then compound 2.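

Replacing 2-bromobenzyl with methyl gives, in this assay, a number 21.4 percentage points lower from compound 2 to compound 3 (beyond the scatter), which shows that the 2-bromophenyl at this position contributes to the read-out of compound 2 and that its loss does not abolish inhibition, since compound 3 still gives 41.7%. Trimming this side of the molecule therefore has no single direction: the earlier removal of a bromo gave a number 22.8 percentage points higher from compound 1 to compound 2 (beyond the scatter), while removal of the whole 2-bromophenyl lowers the number. No measurement shown here accounts for the drop.

Still open, on these data alone, is whether the ring or its bromo matters in the 2-bromobenzyl group, which an unsubstituted benzyl would test, and how an ethyl or a longer chain would read in place of the methyl. As far as these compounds go, whether the number would be higher, lower or level with an amine or a carboxylic acid on that chain also remains open.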